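The source may hold more compounds than are shown below. What is called first, only, known or untested is meant among the compounds shown, and "the series" means these compounds.

Compound 3 `CCCCCCOc1ncc(-c2ccccc2OC)n1C` gives 38000 nM in a functional assay on B16-F10 cells (Mus musculus) for inhibition, read by colorimetric assay and MTT assay, with a stated time of 72 h (on this read-out lower numbers stand for stronger inhibition and higher numbers for weaker inhibition), the lowest of the two numbers reported, though its nearest neighbour, compound 2 `CCCCOc1ncc(-c2ccccc2OC)n1C`, lies within the scatter of it at 71000 nM. Compound 1 `C=CCCCCOc1ccccc1-c1cnc(OCCCC=C)n1C` gives "not determined" (no result reported) in this assay, so no number is reported for it. The step to compound 4 `C#CCCCCOc1ncc(-c2ccccc2OC)n1C` is ethynyl in place of ethyl on a saturated chain carbon, four bonds along the chain from an oxygen on an aromatic ring. Going by the values given here, the one comparable step, a 1.9-fold lower number from compound 2 to compound 3 (0.27 log units; within the scatter), changed the same position and stayed within the scatter, so in this assay no step beyond the scatter is expected for compound 4, in either direction; the data give no step that bears on ethynyl itself. Compound 4 is therefore expected to land near compound 3, at an estimated 40000 nM with a range of 15000 nM to 100000 nM, an expected step of a 1.1-fold higher number from compound 3 to compound 4 (0.02 log units; within the scatter).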

Compound 4, half-maximal inhibitory concentration: 34000 nM
Estimate against measurement, compound 4: 1.2-fold (0.07 log units) above; low and high end bracket the measured number.
By their numbers in this assay, from the lowest: compounds 4, 3 and 2 (each within the scatter of the next, the first and the last beyond it).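

In this assay, going by these compounds alone, ethynyl is the first group with a triple bond seen at this place, and swapping it for ethyl gives a 1.1-fold lower number from compound 3 to compound 4 (0.05 log units; within the scatter), so the two end groups cannot be told apart here. Against the hydrogen at the same place, the result is a 2.1-fold lower number from compound 2 to compound 4 (0.32 log units; beyond the scatter) and this is the first step here that clears the scatter, though only modestly. Nothing available accounts for either step. As far as these compounds go, whether a longer chain, an amine or a carboxylic acid at this place would shift the number further remains open.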